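This account rests on a few compounds, and the source may have more. Where it says the series, first, only, none or still open, it means among the compounds named here.

Two dichloroacetamides of substituted anilines have been tested so far. Compound 1 `O=C(Nc1cccc(I)c1)C(Cl)Cl` and compound 2 `O=C(Nc1ccc(Cl)cc1)C(Cl)Cl` were measured in a functional assay on A549 cells (Homo sapiens) for antiproliferative activity, read by MTT assay, with a stated time of 72 h; a lower number here means a stronger inhibitor, a higher number a weaker inhibitor. Compound 1 gives 4760 nM. Compound 2 gives 20400 nM, the higher of the two numbers, and the gap between them lies beyond the usual scatter. Compound 3 `O=C(Nc1ccc(SC(F)(F)F)cc1)C(Cl)Cl` remains unmeasured; it carries (trifluoromethyl)sulfanyl in place of chloro on an aromatic carbon. Among the measured compounds shown here, no measured pair shows this exact change, so the expected step from compound 2 to compound 3 is a modest one toward a lower number, a 2.3-fold lower number from compound 2 to compound 3 (0.36 log units; beyond the scatter). For compound 3 the expected result in this assay is 9000 nM, within a range of 3000 nM to 27000 nM.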

Compound 3, half-maximal inhibitory concentration: 10600 nM
The estimate for compound 3 lay 1.2-fold (0.07 log units) below the measured number; measured number inside the range.
By their numbers in this assay, from the lowest: compound 1; then compounds 3 and 2 (each within the scatter of the next).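

Among the compounds shown here, replacing chloro with the larger (trifluoromethyl)sulfanyl group at this position gives the first step between two compounds that differ in one place: a 1.9-fold lower number from compound 2 to compound 3 (0.28 log units; within the scatter) in this assay. Here, 5 heavy atoms, including 1 hydrogen-bond acceptor, stand in for a single chlorine atom without a change beyond the scatter. No supporting measurement speaks to the reason for this result.

On these data alone, whether an amine or a carboxylic acid on this aromatic carbon would move the number beyond the scatter remains open.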